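The source may report more compounds than this note shows. Statements on the series, on what has been measured and on what is new or still open speak of the compounds shown alone.

Three compounds have been measured in an assay on isolated protein for inhibition of Nicotinamide phosphoribosyltransferase (Homo sapiens), read by mass spectrometry, with stated times of 15 min and 30 min; on this read-out higher numbers stand for weaker inhibition and lower numbers for stronger inhibition:

Compound 1, `O=S(=O)(c1ccccc1)c1ccc(CNS(=O)(=O)N2Cc3ccncc3C2)cc1`: > 2000 nM.
Compound 2, `CC(C)n1cc(S(=O)(=O)c2ccc(CNC(=O)N3Cc4ccncc4C3)cc2)cn1`: 20 nM.
Compound 3, `O=C(NCc1ccc(S(=O)(=O)C2CCC(F)(F)CC2)cc1)N1Cc2ccncc2C1`: 78 nM.

For compound 1 the value is only a limit of this assay, not a number (the limit of > 2000 nM in this assay, at which 1 of the 3 values shown sits). Among the two real numbers, compound 3 holds the higher one; the nearest is compound 2, and the step of a 3.9-fold higher number from compound 2 to compound 3 (0.59 log units; beyond the scatter) is a modest weakening that lies beyond the scatter. Compound 4, `O=C(NCc1ccc(S(=O)(=O)N2CCC(N3CCCC3)CC2)cc1)N1Cc2ccncc2C1`, differs from compound 3 in one place: 4-(pyrrolidin-1-yl)piperidin-1-yl in place of 4,4-difluorocyclohexyl on a sulfonyl sulfur. Going by the values given here, only the step from compound 2 to compound 3 touches this position, and it covered a different kind of swap, so it gives little guidance here. A small change, within or near the scatter, is therefore expected for compound 4, estimated at 120 nM (range 35 nM to 450 nM), meaning a step of a 1.5-fold higher number from compound 3 to compound 4 (0.19 log units; within the scatter).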

Compound 4, half-maximal inhibitory concentration: 7.4 nM
For compound 4 the middle estimate is 16-fold (1.21 log units) above the measured one; the whole stated range lies above it.
By their numbers in this assay, from the lowest: compound 4; then compound 2; then compound 3. At a limit, above all of these: compound 1.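

In this assay, the sulfonyl sulfur position responds strongly to what it carries: 4-(pyrrolidin-1-yl)piperidin-1-yl in place of 4,4-difluorocyclohexyl gives an 11-fold lower number from compound 3 to compound 4 (1.02 log units; beyond the scatter), a large step. The same group also beats 1-isopropyl-1H-pyrazol-4-yl, with a 2.7-fold lower number from compound 2 to compound 4 (0.43 log units; beyond the scatter), so this position can take a larger two-ring group and still improve. Nothing measured here explains this gain. The compounds shown leave open whether the pyrrolidine ring itself is needed, which a plain piperidine or a morpholine on the same sulfonyl sulfur would test.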